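A few compounds are considered here, and "the series" means these few. Any claim that something is new, unique, unknown or untested is made for them only; others in the source may bear on it.

Compound 1 `CCOC(=O)C1=Cc2ccccc2OC1(OCc1cn(CC(=O)Nc2ccccc2Br)nn1)C(F)(F)F`: in a functional assay on MCF7 cells (Homo sapiens) for inhibition, read by MTT assay, with a stated time of 24 h (a lower number here means a stronger inhibitor, a higher number a weaker inhibitor), compound 1 gives > 150000 nM, which is a limit of the assay.
Compound 2 `CCOC(=O)C1=Cc2ccccc2OC1(OCc1cn(-c2ccc(F)c([N+](=O)[O-])c2)nn1)C(F)(F)F`: in this assay compound 2 gives 16200 nM.

Among the compounds with values here, compound 2 thus holds the only number in this assay; compound 1 sits at the limit of > 150000 nM in this assay, at which 1 of the 2 values shown sits. Within the data shown here, the one measured step, an at least 9.2-fold lower number from compound 1 to compound 2 (0.96 log units; beyond the scatter), swaps the entire group on the aromatic nitrogen, so it bears only loosely on the smaller change to compound 3 `CCOC(=O)C1=Cc2ccccc2OC1(OCc1cn(-c2ccc([N+](=O)[O-])cc2)nn1)C(F)(F)F`, which is 4-nitrophenyl in place of 4-fluoro-3-nitrophenyl on an aromatic nitrogen. Among the measured compounds shown here, no measured step isolates the fluorine. Compound 3 is therefore expected to stay within the scatter of compound 2, with a 1.2-fold higher number from compound 2 to compound 3 (0.09 log units; within the scatter). The estimate for compound 3 is 20000 nM, from 6000 nM to 70000 nM.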

Compound 3, half-maximal inhibitory concentration: > 150000 nM
Compound 3: only a limit was reported; the forecaster's own chance of this, stated with the estimate: 15%; at least 7.5-fold (0.87 log units) between middle value and limit.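

In this assay, 4-nitrophenyl in place of 4-fluoro-3-nitrophenyl gives an at least 9.2-fold higher number from compound 2 to compound 3 (0.96 log units; beyond the scatter) and thus shows that a change far smaller than swapping the entire group on the aromatic nitrogen can matter at this position. As far as these compounds go, compound 3 gives only a limit of the assay, so the true size of this step stays unknown. The step from compound 1 to compound 3 cannot be read, since both values are limits.

This change both removes the fluorine and alters the place of the nitro group, and the compounds shown do not separate the two. From the compounds shown here alone, whether 3-nitrophenyl or 4-fluorophenyl on the same nitrogen would keep the activity of compound 2 remains open.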